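A few compounds are considered here, and "the series" means these few. Any claim that something is new, unique, unknown or untested is made for them only; others in the source may bear on it.

Measured so far, in a functional assay on A2780 cells (Homo sapiens) for inhibition; a lower number here means a stronger inhibitor, a higher number a weaker inhibitor:
compound 1 `CCNCc1cc(-c2c(C(=O)NCC)noc2-c2cc(C(C)C)c(O)cc2O)on1` gives 45 nM
compound 2 `CCNC(=O)c1noc(-c2cc(C(C)C)c(O)cc2O)c1-c1cc(C(=O)OCC)no1` gives 9000 nM

Compound 2 has the highest number of the two, with compound 1 the nearest at a 200-fold higher number from compound 1 to compound 2 (2.30 log units; beyond the scatter). Compound 3 `CCNC(=O)c1noc(-c2cc(C(C)C)c(O)cc2O)c1-c1ccn(C)n1` differs from compound 2 by 1-methyl-1H-pyrazol-3-yl in place of 3-(ethoxycarbonyl)-1,2-oxazol-5-yl on an aromatic carbon. For the measured compounds named here, only one step touches this position, that from compound 1 to compound 2, which was large, so a change of this size is expected to matter in this assay. Since the ester that came in with that step now leaves, a lower number is expected for compound 3, though not a return to compound 1, estimated as a 6.0-fold lower number from compound 2 to compound 3 (0.78 log units; beyond the scatter). The estimate for compound 3 is 1500 nM, between 300 nM and 8000 nM.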

Compound 3, half-maximal inhibitory concentration: 12 nM
Estimate against measurement, compound 3: 130-fold (2.10 log units) above, outside the stated range (below it).
By their numbers in this assay, from the lowest: compound 3; then compound 1; then compound 2.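

In this assay the 1-methyl-1H-pyrazol-3-yl group gives a 750-fold lower number from compound 2 to compound 3 (2.88 log units; beyond the scatter) and also a 3.8-fold lower number from compound 1 to compound 3 (0.57 log units; beyond the scatter) on the same aromatic carbon. A low number at this position therefore needs neither the (ethylamino)methyl group of compound 1 nor a 1,2-oxazol-5-yl ring. Nothing available here explains why this group does so well. Still open, on these data alone, is how much the methyl on the pyrazole ring contributes, and whether a pyrazole without it, or one carrying an amine or a carboxylic acid, would keep a number this low.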